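A few compounds are considered here, and "the series" means these few. Any claim that something is new, unique, unknown or untested is made for them only; others in the source may bear on it.

Measured so far in a functional assay on A549 cells (Homo sapiens) for cytotoxicity; on this read-out higher numbers stand for weaker inhibition and lower numbers for stronger inhibition:
- compound 1 `Cc1ccc(S(=O)(=O)N2C(=O)NCC2c2ccccc2)cc1`: > 316000 nM
- compound 2 `O=C1NC(c2ccccc2)CN1S(=O)(=O)c1ccccc1`: 145000 nM
- compound 3 `Cc1ccc(C2CNC(=O)N2S(=O)(=O)c2ccc3c(c2)CCC3)cc1`: 90300 nM

Compound 1 has only a limit of the assay and no exact number: the limit of > 316000 nM in this assay, at which 1 of the 3 values shown sits. Compound 2 and compound 3 have true numbers, and these lie within the usual scatter of each other.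

Compound 4 `Cc1ccc(C2CNC(=O)N2S(=O)(=O)c2ccc(C)cc2)cc1` differs from compound 1 in one place: methyl in place of hydrogen on an aromatic carbon. This puts methyl in place of hydrogen on an aromatic carbon, turning phenyl into 4-methylphenyl. Within the data shown here, no measured pair shows this change on its own, so any step here is an expectation only.

Compound 3 also carries a 4-methylphenyl on the shared core, and in this assay compound 3 gives 90300 nM. A true number for compound 4 therefore seems possible, though another limit would be no surprise. The expected step of an at least 1.7-fold lower number from compound 1 to compound 4 (0.24 log units; that floor lies within the scatter) is modest and points toward stronger inhibition. For compound 4 the estimated value is 180000 nM, with an expected range of 80000 nM to 316000 nM.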

Compound 4, half-maximal inhibitory concentration: > 302000 nM
Compound 4: only a limit was reported; the forecaster's own chance of this, stated with the estimate: 35%; middle value at least 1.6-fold (0.22 log units) away from the limit.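

Compound 1 and compound 4 each have only a limit in this assay, not a true number, so no step can be read between them. The compounds shown leave open whether turning phenyl into 4-methylphenyl changes inhibition at all.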